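The compounds below may be only part of what the source reports. "The series", "measured", "known", "first", "only" and "open" are said of these compounds alone.

Working notes on the series. Compound 1 `O=c1cc(-c2ccccc2)oc2cc(OCc3ccccc3)c(OCCCCN3CCCCC3)c(O)c12` gives 2400 nM in a functional assay on HepG2 cells (Homo sapiens) for antiproliferative activity, read by MTT assay, with a stated time of 48 h; on this read-out higher numbers stand for weaker inhibition and lower numbers for stronger inhibition. Compound 2 `O=c1cc(-c2ccccc2)oc2cc(O)c(OCCCCN3CCCCC3)c(O)c12` sits at the limit of this assay, > 100000 nM. The step from compound 1 to compound 2, hydrogen in place of benzyl on an oxygen on an aromatic ring, reads an at least 41-fold higher number from compound 1 to compound 2 (1.61 log units; beyond the scatter); the size rests on (the limit of > 100000 nM in this assay, at which 1 of the 3 values shown sits). Compound 3 `COc1cc2oc(-c3ccccc3)cc(=O)c2c(O)c1OCCCCN1CCN(C)CC1` gives 36700 nM in this assay, the highest of the two numbers shown, with compound 1 nearest at a lower number.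

Compound 4 `COc1cc2oc(-c3ccccc3)cc(=O)c2c(O)c1OCCCCN1CCCCC1` differs from compound 3 by piperidin-1-yl in place of 4-methylpiperazin-1-yl on a saturated chain carbon, four bonds along the chain from an oxygen on an aromatic ring. Among the compounds with values here, no measured step touches this part of the molecule: the single step from compound 1 to compound 2 concerns the benzyl on the aromatic oxygen. Compound 1 carries piperidin-1-yl, but it differs from compound 3 elsewhere as well, so the two values only loosely bracket the outcome. A moderate step toward lower numbers, near the edge of the scatter, is expected, a 2.4-fold lower number from compound 3 to compound 4 (0.39 log units; beyond the scatter). Compound 4 is estimated at 15000 nM in this assay, with a range from 5000 nM to 50000 nM.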

Compound 4, half-maximal inhibitory concentration: 21000 nM
For compound 4 the middle estimate is 1.4-fold (0.15 log units) below the measured one; the measured number falls inside the stated range.
By their numbers in this assay, from the lowest: compound 1; then compounds 4 and 3 (each within the scatter of the next). At a limit, above all of these: compound 2.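

In this assay the pair reads a 1.7-fold lower number from compound 3 to compound 4 (0.24 log units; within the scatter), so piperidin-1-yl and 4-methylpiperazin-1-yl on this chain are not told apart here. Compound 2 stands at a limit, so methyl in place of hydrogen on the aromatic oxygen reads an at least 4.7-fold lower number from compound 2 to compound 4 (0.67 log units; beyond the scatter), which is a bound only: the limit of > 100000 nM in this assay, at which 1 of the 4 values shown sits. The group on that same oxygen carries the larger differences, with hydrogen in place of phenyl on its saturated chain carbon reading an 8.8-fold higher number from compound 1 to compound 4 (0.94 log units; beyond the scatter), so that among compounds 1, 2 and 4 the numbers fall from hydrogen through methyl to benzyl.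

Open, as far as these compounds go, is whether the ring amine at the chain end matters at all, which a morpholine or a simple dimethylamino group would test, as would a shorter or longer chain. Also open, from the compounds shown here alone, is whether a benzyl on that oxygen paired with 4-methylpiperazin-1-yl would read like compound 1, or whether a substituted benzyl would go further.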